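A pyrimidine-bearing group replaces a fluorobenzyl group

The compounds below may be only part of what the source reports. "The series", "measured", "known", "first", "only" and "open" are said of these compounds alone.

In an ADME assay on MT4 cells (Homo sapiens) for cytotoxicity, read by MTT assay (a higher number here means that more compound is tolerated, a lower number that less compound is tolerated), compound 3 (`Cc1cc(C)cc(S(=O)(=O)c2c(C(=O)NCC(=O)NCc3ccccc3F)[nH]c3ccc(Cl)cc23)c1`) gives > 47300 nM, which is a limit of the assay and not a number. Compound 2 (`Cc1cc(C)cc(S(=O)(=O)c2c(C(=O)NCC(=O)NCc3ccncn3)[nH]c3ccc(Cl)cc23)c1`) gives > 48800 nM, which is also a limit. Compound 1 (`Cc1cc(C)cc(S(=O)(=O)c2c(C(=O)NC(C)C(=O)NC(C)c3ccccc3F)[nH]c3ccc(Cl)cc23)c1`) is the only one of the three with a number, at 15200 nM.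

Compound 4 (`Cc1cc(C)cc(S(=O)(=O)c2c(C(=O)NC(C)C(=O)NCc3ccncn3)[nH]c3ccc(Cl)cc23)c1`) departs from compound 3 on an amide-type nitrogen: a group of 12 heavy atoms (8 carbon, 3 nitrogen, 1 oxygen; one six-membered aromatic ring with 2 hetero atoms) in place of a group of 12 heavy atoms (9 carbon, 1 nitrogen, 1 oxygen, 1 fluorine; one six-membered aromatic ring of carbon only), on an amide-type nitrogen. The measured step that bears most directly on this is a step that the two limits leave unreadable from compound 2 to compound 3, and it offers no size to carry over. Its exchange of rings runs the opposite way here. With so little to go on, no step beyond the scatter is expected, although the number for compound 1 of 15200 nM keeps the lower side open. The expected step is an at least 1.1-fold lower number from compound 3 to compound 4 (0.07 log units; that floor lies within the scatter). Compound 4 is estimated at 40000 nM, with an expected range from 15000 nM to 60000 nM.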

Compound 4, half-maximal cytotoxic concentration: 28100 nM
Compound 4: middle estimate off by 1.4-fold (0.15 log units), on the high side; the range from low to high includes it.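

In this assay, methyl in place of hydrogen on the saturated chain carbon gives an at least 1.7-fold lower number from compound 2 to compound 4 (0.23 log units; that floor lies within the scatter), and the exchange of groups on the amide-type nitrogen gives an at least 1.6-fold lower number from compound 3 to compound 4 (0.22 log units; that floor lies within the scatter). Compound 2 and compound 3 each stand at a limit of the assay and not at a number, so these two steps are floors only, and the step between those two compounds cannot be read. With the methyl present, (pyrimidin-4-yl)methyl in place of 1-(2-fluorophenyl)ethyl on the amide-type nitrogen gives a 1.8-fold higher number from compound 1 to compound 4 (0.27 log units; within the scatter), so the two groups are not told apart here.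

On these data alone, the true size of the methyl step stays open. So does how the number would respond to an ethyl group or a carboxylic acid on that chain carbon.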